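The compounds below may be only part of what the source reports. "The series", "measured", "known", "first", "only" and "open" are said of these compounds alone.

Among the measured compounds shown here, compound 2 `CCC1(OC(=O)N2CCC(Oc3ncnc(Oc4ccc(S(C)(=O)=O)nc4C)c3F)CC2)CC1` gives the lowest of the two numbers so far in a functional assay on isolated protein for inhibition of Glucose-dependent insulinotropic receptor (Homo sapiens), read by HTRF and cAMP accumulation (on this read-out higher numbers stand for an effect only at larger amounts of compound and lower numbers for an effect already at smaller amounts), with 22 nM; compound 1 `Cc1nc(S(C)(=O)=O)ccc1Oc1ncnc(OC2CCN(C(=O)O[C@H](C)CF)CC2)c1F` gives 196 nM in this assay. For the measured compounds named here, the one measured step, an 8.9-fold lower number from compound 1 to compound 2 (0.95 log units; beyond the scatter), touched the same oxygen next to a carbonyl group and moved the number well beyond the scatter. Compound 3 `Cc1nc(S(C)(=O)=O)ccc1Oc1ncnc(OC2CCN(C(=O)OC3(C(F)(F)F)CCC3)CC2)c1F` carries 1-(trifluoromethyl)cyclobutyl in place of 1-ethylcyclopropyl on an oxygen next to a carbonyl group. Going by the values given here, no measured step covers this exact exchange, so the expectation for compound 3 rests on compound 2 and is a change of a 1.1-fold higher number from compound 2 to compound 3 (0.06 log units; within the scatter), within the scatter. Compound 3 is estimated at 25 nM, between 8 nM and 80 nM.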

Compound 3, half-maximal effective concentration: 14.3 nM
Compound 3: the middle estimate sits 1.7-fold (0.24 log units) above what was measured; measured number inside the range.
By their numbers in this assay, from the lowest: compounds 3 and 2 (each within the scatter of the next); then compound 1.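

In this assay, the oxygen next to a carbonyl group takes 1-(trifluoromethyl)cyclobutyl, with its four-membered ring and three fluorine atoms, in place of 1-ethylcyclopropyl with little effect (a 1.5-fold lower number from compound 2 to compound 3 (0.19 log units; within the scatter)). Set against 1-(fluoromethyl)ethyl, the same group gives (a 14-fold lower number from compound 1 to compound 3 (1.14 log units; beyond the scatter)), so both ring-bearing groups stand clear of compound 1. Nothing available accounts for these results. The compounds shown leave open what an amine or a longer chain on this oxygen would give. They also do not separate the trifluoromethyl from the ring size.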